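Imidazolyl Chalcone Estimated From Three Measured Analogues

The source may report more compounds than this note shows. Statements on the series, on what has been measured and on what is new or still open speak of the compounds shown alone.

The measured compounds:
compound 1, `COc1ccc(C(=O)/C=C/c2ccc(Br)cc2)c2c1C=CC(C)(C)O2`, > 10000 nM
compound 2, `COc1ccc(C(=O)/C=C/c2ccc(-c3ccccc3)cc2)c2c1C=CC(C)(C)O2`, > 10000 nM
compound 3, `COc1ccc(C(=O)/C=C/c2ccc(N3CCCC3)cc2)c2c1C=CC(C)(C)O2`, 7150 nM

The three compounds share one core and differ only in the group on the terminal benzene ring. In a functional assay on SW-620 cells (Homo sapiens) for antiproliferative activity, read by MTT assay, with a stated time of 24 h (on this read-out higher numbers stand for weaker inhibition and lower numbers for stronger inhibition), compound 1 gives > 10000 nM, which is a limit of the assay and not a number. In this assay compound 2 gives > 10000 nM, likewise a limit. In this assay, among the compounds with values here, compound 3 gives 7150 nM, the only number among the three; the other two values sit at the limit of > 10000 nM in this assay, at which 2 of the 3 values shown sit. The step that the two limits leave unreadable from compound 1 to compound 2 therefore cannot be read. Within the data shown here, the steps of an at least 1.3-fold lower number from compound 1 to compound 3 (0.14 log units; that floor lies within the scatter) and an at least 1.3-fold lower number from compound 2 to compound 3 (0.14 log units; that floor lies within the scatter) show only that compound 3 reaches a number where the others do not.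

Compound 4, `COc1ccc(C(=O)/C=C/c2ccc(-n3ccnc3)cc2)c2c1C=CC(C)(C)O2`, differs from compound 3 by 1H-imidazol-1-yl in place of pyrrolidin-1-yl on an aromatic carbon. Among the measured compounds shown here, no measured step compares two such five-membered groups, so only the position of compound 3 in this assay guides the expectation. Compound 4 is expected to sit close to compound 3, with a step of a 1.1-fold higher number from compound 3 to compound 4 (0.05 log units; within the scatter) that stays within the scatter. The value of compound 4 in this assay is estimated at 8000 nM, between 3000 nM and 20000 nM.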

Compound 4, half-maximal inhibitory concentration: > 10000 nM
Compound 4: a limit, no number; the forecaster's own chance of this, stated with the estimate: 45%; at least 1.2-fold (0.09 log units) between middle value and limit.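

In this assay compound 4 gives > 10000 nM, which is a limit of the assay and not a number. The step is an at least 1.3-fold higher number from compound 3 to compound 4 (0.14 log units; that floor lies within the scatter), so the change to 1H-imidazol-1-yl on an aromatic carbon para to a large group, with the same count of heavy atoms and a five-membered ring still in place, does not retain a measurable value, although the floor of this step does not clear the scatter. The steps linking compound 4 to compound 1 and compound 2 cannot be read, and pyrrolidin-1-yl remains the only group at this place that gives a number: the limit of > 10000 nM in this assay, at which 3 of the 4 values shown sit.

Going by these compounds, how far compound 1, compound 2 and compound 4 lie past that limit remains unknown, so no order among the bromo, phenyl and 1H-imidazol-1-yl groups can be drawn. The compounds shown also leave open whether the number seen for compound 3 is particular to pyrrolidin-1-yl or extends to other saturated amines at this place, such as piperidin-1-yl, morpholin-4-yl or an open-chain dimethylamino group.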